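Methyl to Hydrogen on an Aromatic Oxygen in Three Diaryl Ureas

This account rests on a few compounds, and the source may have more. Where it says the series, first, only, none or still open, it means among the compounds named here.

Compound 1, `COc1cc(-c2nn(-c3cccc(NC(=O)Nc4cc(C(F)(F)F)cc(C(F)(F)F)c4)c3)cc2-c2ccncc2)ccc1Cl`, gives 702 nM in a functional assay on HT-29 cells (Homo sapiens) for inhibition, read by sulforhodamine B assay, with a stated time of 48 h; on this read-out higher numbers stand for weaker inhibition of growth and lower numbers for stronger inhibition of growth. Compound 2, `O=C(Nc1cccc(-n2cc(-c3ccncc3)c(-c3ccc(Cl)c(O)c3)n2)c1)Nc1cc(C(F)(F)F)cc(C(F)(F)F)c1`, gives 746 nM in this assay. Compound 3, `COc1cc(-c2nn(-c3cccc(NC(=O)Nc4ccc(Cl)c(C(F)(F)F)c4)c3)cc2-c2ccncc2)ccc1Cl`, gives 1190 nM in this assay.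

Compound 2 differs from compound 1 in one place: hydrogen in place of methyl on an oxygen on an aromatic ring. This change produced a 1.1-fold higher number from compound 1 to compound 2 (0.03 log units; within the scatter), so the two compounds cannot be told apart on this read-out. Compound 3 carries a different urea end; the difference between its core and that of compound 1 is not broken down here, and its value and that of compound 1 lie within the scatter of each other.

Compound 4, `O=C(Nc1cccc(-n2cc(-c3ccncc3)c(-c3ccc(Cl)c(O)c3)n2)c1)Nc1ccc(Cl)c(C(F)(F)F)c1`, is not yet measured. It differs from compound 3 by hydrogen in place of methyl on an oxygen on an aromatic ring. The place is the same word for word as in the pair of compound 1 and compound 2, so this is the same change. Going by the values given here, the step from compound 3 to compound 4 in this assay is expected to be a 1.1-fold higher number from compound 3 to compound 4 (0.02 log units; within the scatter), because the same change gave a 1.1-fold higher number from compound 1 to compound 2 (0.03 log units; within the scatter) in the only pair where it has been measured. Compound 4 is therefore estimated at 1250 nM, with a likely range from 600 nM to 2600 nM.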

Compound 4, concentration for 50% growth inhibition: 1280 nM
Beside the measured number, compound 4's estimate is 1.0-fold (0.01 log units) below it; the range from low to high includes it.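

The methoxy to hydroxy change gave a 1.1-fold higher number from compound 3 to compound 4 (0.03 log units; within the scatter) in this assay. Set beside the earlier pair, the step shows that the change behaved alike on the two cores, which carry different urea ends: the same change on two cores in this assay, a 1.1-fold higher number (0.03 log units; within the scatter) from compound 1 to compound 2 and a 1.1-fold higher number (0.03 log units; within the scatter) from compound 3 to compound 4, 1.0-fold (0.01 log units) apart, within the scatter of two such steps. On both cores, the swap of 4-chloro-3-methoxyphenyl for 4-chloro-3-hydroxyphenyl left the read-out within the scatter, but two pairs do not show that this would hold on other cores in the series, and a step this small says nothing about what either group contributes to growth inhibition.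

The compounds shown leave open whether an ethoxy group or an amine in that place on the aromatic ring would give a step beyond the scatter. They also leave open how the methoxy to hydroxy change would read on a urea end other than the two seen here, or in a read-out other than this one.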